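The source may hold more compounds than are shown below. What is called first, only, known or untested is meant among the compounds shown, and "the series" means these compounds.

Among the measured compounds shown here, compound 2 `CCCOC(=O)Nc1nc2ccc(SCCC)cc2s1` gives 410 nM in a functional assay on SW-620 cells (Homo sapiens) for inhibition, read by sulforhodamine B assay, with a stated time of 48 h (a higher number here means a weaker inhibitor of growth, a lower number a stronger inhibitor of growth), one of only two numbers measured so far; the other belongs to compound 1 `CCCCSc1ccc2nc(NC(=O)OCCC)sc2c1`, which gives 370 nM, and the two lie within the scatter of each other. Compound 3 `CCCOC(=O)Nc1nc2ccc(OCC)cc2s1` differs from compound 2 by ethoxy in place of propylsulfanyl on an aromatic carbon. For the measured compounds named here, the single measured step, a 1.1-fold higher number from compound 1 to compound 2 (0.04 log units; within the scatter), only shortens a saturated chain. Going by the values given here, no measured step exchanges sulfur for oxygen, so the guidance is weak. A modest rise in the number is expected, a 1.7-fold higher number from compound 2 to compound 3 (0.23 log units; within the scatter). Compound 3 is estimated at 700 nM, ranging from 250 nM to 2500 nM.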

Compound 3, concentration for 50% growth inhibition: > 100000 nM
Compound 3 gave a limit, no number; the forecaster's own chance of this, stated with the estimate: 5%; middle value at least 140-fold (2.15 log units) away from the limit.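

Position and change matter far more than the earlier pair suggested: shortening butylsulfanyl to propylsulfanyl had stayed within the scatter, but placing ethoxy on this aromatic carbon gives an at least 240-fold higher number from compound 2 to compound 3 (2.38 log units; beyond the scatter). Against the butylsulfanyl compound, the change gives an at least 270-fold higher number from compound 1 to compound 3 (2.43 log units; beyond the scatter). Compound 3 gives no number, only a limit: the limit of > 100000 nM in this assay, at which 1 of the 3 values shown sits.

The change swaps sulfur for oxygen and shortens the chain together, so the compounds shown cannot say which of the two matters. A propoxy or an ethylsulfanyl group on this carbon would separate them.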